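Methylation of a phenol in two urea and amide series

The compounds below may be only part of what the source reports. "The series", "measured", "known", "first", "only" and "open" are said of these compounds alone.

In a functional assay on DU-145 cells (Homo sapiens) for inhibition, read by sulforhodamine B assay, with a stated time of 48 h, tested at 10 uM (on this read-out lower numbers stand for a stronger effect and higher numbers for a weaker effect at the one concentration tested), compound 1 `O=C(Nc1cccc(-n2cc(-c3ccncc3)c(-c3cc(O)cc(Cl)c3)n2)c1)Nc1ccc(Cl)c(Cl)c1` gives -15.1%. Compound 2 `COc1cc(Cl)cc(-c2nn(-c3cccc(NC(=O)Nc4ccc(Cl)c(Cl)c4)c3)cc2-c2ccncc2)c1`, in this assay, gives 12.1%. The change between them is methyl in place of hydrogen on an oxygen on an aromatic ring and it made a step of a number 27.2 percentage points higher from compound 1 to compound 2 (beyond the scatter). Compound 3 `O=C(Nc1cccc(-n2cc(-c3ccncc3)c(-c3cc(O)cc(Cl)c3)n2)c1)c1cc(C(F)(F)F)cc(C(F)(F)F)c1` gives 62.1% in this assay, the highest of the three numbers; its gap to compound 2 and to compound 1 both lie beyond the scatter. The difference between the core of compound 3 and the core of compound 1 is not broken down here.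

Compound 4 `COc1cc(Cl)cc(-c2nn(-c3cccc(NC(=O)c4cc(C(F)(F)F)cc(C(F)(F)F)c4)c3)cc2-c2ccncc2)c1` has not yet been measured. It differs from compound 3 by methyl in place of hydrogen on an oxygen on an aromatic ring, the same kind of change as that from compound 1 to compound 2, at a place described in the same words. Among the compounds with values here, on the single earlier step alone, the expected step from compound 3 to compound 4 in this assay is a number 17.9 percentage points higher from compound 3 to compound 4 (beyond the scatter), set beside the earlier a number 27.2 percentage points higher from compound 1 to compound 2 (beyond the scatter) and resting on the fact that compound 3 already starts from 62.1%, so that the read-out has less room to rise. Within the data shown here, compound 4 is therefore estimated to give about 80% in this assay, with a range from 58% to 100% that allows the step to be smaller than the earlier one, since only one prior example supports it.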

Compound 4, a percentage reported as activity, at one concentration (the size of the read-out at that concentration, not a potency): 78.2%
Compound 4: the middle estimate sits 1.8 percentage points above what was measured, and the stated range covers the measured number.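

In this assay, replacing hydroxy with methoxy on the 3-chloro-5-hydroxyphenyl group raised the number on the second core as well, with a step of a number 16.1 percentage points higher from compound 3 to compound 4 (beyond the scatter), so in both pairs shown the methylated compound gives the higher number, which on this read-out stands for a weaker effect. Within the data shown here, this supports carrying the direction of the change from the urea compounds to the amide compounds, but it rests on only two pairs, gives no rule for any further core, and, coming from one concentration, describes the size of the read-out and not a potency. Set side by side, the two steps do not differ measurably, so the data give no sign that the size of the step depends on the core: the same change on two cores in this assay, a number 27.2 percentage points higher (beyond the scatter) from compound 1 to compound 2 and a number 16.1 percentage points higher (beyond the scatter) from compound 3 to compound 4, 11.1 percentage points apart, within the scatter of two such steps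

The compounds shown leave open whether the rise belongs to methyl in particular or would also appear with a longer chain such as ethyl or with an amine in place of the hydroxy group. They also leave open how the change would read across a range of concentrations or in cells other than the one line used here, and whether it would hold on a core carrying a different group at the urea or amide end.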